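The source may report more compounds than this note shows. Statements on the series, on what has been measured and on what is new or still open speak of the compounds shown alone.

Compound 1 `CCOC(=O)/C=C/C(=O)N(CC(N)=O)NC(=O)[C@@H]1CCCN1C(C)=O` gives 8.3 nM in an assay on isolated protein for inhibition of legumain (Mus musculus), read by fluorescence, with stated times of 30 s and 2.5 h; a lower number here means a stronger inhibitor, a higher number a weaker inhibitor.
Compound 2 `CCOC(=O)/C=C/C(=O)N(CC(N)=O)NC(=O)[C@@H]1CCCN1C(=O)[C@H]1CCCCN1C(C)=O` gives 638 nM in this assay.
Compound 3 `C/C=C(\NC(C)=O)C(=O)N1CCC[C@H]1C(=O)NN(CC(N)=O)C(=O)/C=C/C(=O)OCC` gives 141 nM in this assay.

Compound 3 stands second highest of the three numbers in this assay. Compound 4 `CCOC(=O)/C=C/C(=O)N(CC(N)=O)NC(=O)[C@@H]1CCCN1C(=O)C(C)(C)NC(C)=O` differs from it by a group of 7 heavy atoms (5 carbon, 1 nitrogen, 1 oxygen; no ring) in place of a group of 7 heavy atoms (5 carbon, 1 nitrogen, 1 oxygen; no ring), on a carbonyl carbon. Within the data shown here, the steps that bear on this place are a 17-fold higher number from compound 1 to compound 3 (1.23 log units; beyond the scatter) and a 77-fold higher number from compound 1 to compound 2 (1.89 log units; beyond the scatter), both enlargements of the acetyl group in compound 1, and a 4.5-fold lower number from compound 2 to compound 3 (0.66 log units; beyond the scatter), an exchange of one larger group for another. Among the measured compounds shown here, no measured step exchanges two groups of equal size at this carbonyl carbon, so compound 4 is expected to lie near compound 3, with a step of a 1.1-fold higher number from compound 3 to compound 4 (0.03 log units; within the scatter) in this assay that need not exceed the scatter. Compound 4 is estimated at 150 nM, in a range from 50 nM to 500 nM.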

Compound 4, half-maximal inhibitory concentration: 198 nM
Estimate against measurement, compound 4: 1.3-fold (0.12 log units) below; the measured number falls inside the stated range.
By their numbers in this assay, from the lowest: compound 1; then compounds 3 and 4 (each within the scatter of the next); then compound 2.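

On this carbonyl carbon, in this assay, 1-acetamido-1-methylethyl and the group it replaces, equal in heavy atoms but differing in double bonds, are not told apart (a 1.4-fold higher number from compound 3 to compound 4 (0.15 log units; within the scatter)). Replacing methyl with 1-acetamido-1-methylethyl still carries a large penalty (a 24-fold higher number from compound 1 to compound 4 (1.38 log units; beyond the scatter)), while replacing the ring-bearing group of compound 2 gives a modest gain (a 3.2-fold lower number from compound 2 to compound 4 (0.51 log units; beyond the scatter)). No evidence explains these steps. The compounds shown leave open how an ethyl group would compare with methyl at this place, and whether a free amine in place of the acetamido part would change the number.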